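Methoxy to Hydroxy on a Shared Benzimidazole Core

The source may report more compounds than this note shows. Statements on the series, on what has been measured and on what is new or still open speak of the compounds shown alone.

Measured so far:
compound 1 `COc1ccc(-c2nc3cc(Cl)c(Cl)cc3[nH]2)cc1`: 1000 nM
compound 2 `Oc1ccc(-c2nc3cc(C(F)(F)F)ccc3[nH]2)cc1`: 17000 nM
compound 3 `CN1CCN(CC(=O)Nc2ccc(-c3nc4cc(Cl)c(Cl)cc4[nH]3)cc2)CC1`: 11000 nM

In an ADME assay on MT4 cells (Homo sapiens) for cytotoxicity, read by MTT assay, with a stated time of 96 h (on this read-out higher numbers stand for lower toxicity in this test and lower numbers for higher toxicity in this test), compound 1 gives 1000 nM, the lowest of the three numbers, which here means the strongest effect on the cells. Compound 3 gives 11000 nM, the nearest of the other two, and compound 2 gives 17000 nM, the furthest; both gaps from compound 1 lie beyond the usual scatter of this test. For the measured compounds named here, no two measured compounds differ in only one place, so no single measured step is available.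

Compound 4 `Oc1ccc(-c2nc3cc(Cl)c(Cl)cc3[nH]2)cc1` differs from compound 1 in one place: hydrogen in place of methyl on an oxygen on an aromatic ring. Cut one bond further out, the change reads methoxy to hydroxy. Compound 2 also carries a hydroxy, but on a core with a different substituent, so its value is only a loose hint.

The step of a 3.0-fold higher number from compound 1 to compound 4 (0.48 log units; beyond the scatter) is expected to be a moderate rise, beyond the scatter, partly because compound 2 gives 17000 nM. Compound 4 is estimated at 3000 nM, within a range of 800 nM to 15000 nM.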

Compound 4, half-maximal cytotoxic concentration: 12000 nM
Beside the measured number, compound 4's estimate is 4.0-fold (0.60 log units) below it, within the range that was stated.
By their numbers in this assay, from the lowest: compound 1; then compounds 3, 4 and 2 (each within the scatter of the next).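

In this assay, for the compounds shown here, putting hydrogen in place of methyl on an oxygen on an aromatic ring gives a 12-fold higher number from compound 1 to compound 4 (1.08 log units; beyond the scatter) and is the first step here that can be read at a single place. With the rest of the molecule unchanged, this one position alone can move the number by a large amount, and going from methoxy to hydroxy raises it, which on this read-out stands for lower toxicity in this test. Nothing available here accounts for the size of this step.

Going by these compounds, this is a single pair on a single core, so whether the same change has a similar effect on other cores remains open. The compounds shown also leave open how an ethoxy group, a longer chain on that oxygen or an amine in place of the hydroxy would read.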